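Adding a Methoxy Group to a Bis-Benzylidene Cyclohexanone

The compounds below may be only part of what the source reports. "The series", "measured", "known", "first", "only" and "open" are said of these compounds alone.

Measured so far in a functional assay on SW-620 cells (Homo sapiens) for cytotoxicity, read by MTT assay, with a stated time of 72 h; on this read-out lower numbers stand for stronger inhibition and higher numbers for weaker inhibition:
compound 1, `COc1cccc(/C=C2\CCC/C(=C\c3cccc(OC)c3OC)C2=O)c1`, 7000 nM;
compound 2, `COc1cc(/C=C2\CCC/C(=C\c3cccc(OC)c3OC)C2=O)cc(OC)c1`, 3800 nM;
compound 3, `COc1cc(/C=C2\CCC/C(=C\c3ccc(OC)c(OC)c3)C2=O)cc(OC)c1`, 2500 nM.

From compound 1 to compound 2 the change is methoxy in place of hydrogen on an aromatic carbon, and it gave a 1.8-fold lower number from compound 1 to compound 2 (0.27 log units; within the scatter). Compound 4, `COc1ccc(/C=C2\CCC/C(=C\c3cc(OC)c(OC)c(OC)c3)C2=O)cc1OC`, is not yet measured. It arises from compound 3 by methoxy in place of hydrogen on an aromatic carbon. Among the compounds with values here, this is the same kind of change as the one from compound 1 to compound 2, though the surroundings differ: there the new methoxy sat meta to a large group and meta to a methoxy group, here it sits ortho to two methoxy groups and para to a large group. The difference between the cores of compound 1 and compound 3 is not broken down here. Compound 3 gives the lowest of the three numbers, with compound 2 within the scatter of it and compound 1 beyond it. The expected step is a 1.3-fold lower number from compound 3 to compound 4 (0.10 log units; within the scatter), because the earlier step of a 1.8-fold lower number from compound 1 to compound 2 (0.27 log units; within the scatter) of compounds 1 and 2 stayed within the scatter. Compound 4 is therefore expected at 2000 nM, between 800 nM and 5000 nM.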

Compound 4, half-maximal inhibitory concentration: 1800 nM
Compound 4: the middle estimate sits 1.1-fold (0.05 log units) above what was measured; the range from low to high includes it.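

In this assay, methoxy in place of hydrogen on an aromatic carbon gave a 1.4-fold lower number from compound 3 to compound 4 (0.14 log units; within the scatter). Set beside the earlier step, the change looks alike on the two cores: the same change on two cores in this assay, a 1.8-fold lower number (0.27 log units; within the scatter) from compound 1 to compound 2 and a 1.4-fold lower number (0.14 log units; within the scatter) from compound 3 to compound 4, 1.3-fold (0.12 log units) apart, within the scatter of two such steps Each step on its own also stays within the scatter, and two cores are few, so this does not show that the methoxy group truly lowers the number, nor that the change would carry to other cores in the series.

The compounds shown carry only methoxy groups on their aromatic rings. On these data alone, whether an amine, a carboxylic acid or a longer chain on such a carbon would give a step beyond the scatter remains open.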